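The source may hold more compounds than are shown below. What is called first, only, known or untested is meant among the compounds shown, and "the series" means these compounds.

Three compounds that share one core were tested in a functional assay on DU-145 cells (Homo sapiens) for antiproliferative activity, read by sulforhodamine B assay; on this read-out lower numbers stand for stronger inhibition and higher numbers for weaker inhibition. Compound 1 `CCCCCCCCCCCCCCCCCCNC(=O)[C@@H]1CSC(c2cccc(O)c2)N1` gives 5700 nM. Compound 2 `CCCCCCCCCCCCCCCCCCNC(=O)[C@@H]1CSC(c2ccc(OC)cc2)N1` gives 8700 nM, and compound 3 `CCCCCCCCCCCCCCCCCCNC(=O)[C@@H]1CSC(c2ccc(N(C)C)cc2)N1` gives 5300 nM. Compound 3 has the lowest of the three numbers, though all three lie within the scatter of one another: the steps of a 1.1-fold lower number from compound 1 to compound 3 (0.03 log units; within the scatter) and a 1.6-fold lower number from compound 2 to compound 3 (0.22 log units; within the scatter) are both small, so none of the three can be set apart. Compound 4 `CCCCCCCCCCCCCCCCCCNC(=O)[C@@H]1CSC(c2ccc(OCC)cc2)N1` is the next compound to be measured. It differs from compound 3 in one place: ethoxy in place of dimethylamino on an aromatic carbon. The step that bears most on this change is a 1.6-fold lower number from compound 2 to compound 3 (0.22 log units; within the scatter), in which methoxy gave way to dimethylamino on an aromatic carbon without moving beyond the scatter; the step of a 1.5-fold higher number from compound 1 to compound 2 (0.18 log units; within the scatter) likewise stayed within it. Swapping one such group for another on this ring has so far left the number where it was, so for compound 4 no step beyond the scatter is expected, a 1.3-fold higher number from compound 3 to compound 4 (0.12 log units; within the scatter). Compound 4 is therefore estimated at 7000 nM, with a range from 3500 nM to 14000 nM.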

Compound 4, half-maximal inhibitory concentration: > 20000 nM
Compound 4: no number, only a limit; the forecaster's own chance of this, stated with the estimate: 5%; at least 2.8-fold (0.45 log units) between middle value and limit.
By their numbers in this assay, from the lowest: compounds 3, 1 and 2 (each within the scatter of the next). At a limit, above all of these: compound 4.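

In this assay compound 4 gives no number, only a limit: the limit of > 20000 nM in this assay, at which 1 of the 4 values shown sits. Even so, all three steps to it lie beyond the scatter, an at least 3.7-fold higher number from compound 3 to compound 4 (0.57 log units; beyond the scatter), an at least 2.2-fold higher number from compound 2 to compound 4 (0.36 log units; beyond the scatter) and an at least 3.5-fold higher number from compound 1 to compound 4 (0.54 log units; beyond the scatter), whereas no earlier change on this aromatic ring had done so. The step from compound 2 shows that a single methyl in place of hydrogen on the chain carbon bound to the oxygen is enough, so at this place, para to a large group, ethoxy and dimethylamino are not interchangeable even with equal counts of heavy atoms and hydrogen-bond acceptors.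

From the compounds shown here alone, how far compound 4 lies past its limit stays unknown. Going by these compounds, it also stays open whether a longer chain on the oxygen, such as propoxy, or a larger amine, such as diethylamino, would behave like ethoxy or like dimethylamino.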